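This account rests on a few compounds, and the source may have more. Where it says the series, first, only, none or still open, it means among the compounds named here.

Of the compounds shown here, three with a shared core have already been measured in a functional assay on HCT-116 cells (Homo sapiens) for inhibition, read by MTT assay, with a stated time of 48 h; on this read-out higher numbers stand for weaker inhibition and lower numbers for stronger inhibition. Compound 1 `COc1ccc(CN(C(=O)CCl)c2cc(OC)c(OC)c(OC)c2)cc1O` gives 250 nM in this assay. Compound 2 `COc1ccc(CNc2cc(OC)c(OC)c(OC)c2)cc1Br`, which differs more widely from the other two, gives 48100 nM in this assay. Compound 3 `COc1ccc(CN(C(=O)CCCl)c2cc(OC)c(OC)c(OC)c2)cc1O` gives 150 nM in this assay. Among these three numbers compound 3 stands lowest; its nearest neighbour is compound 1, and the single measured step shows a 1.7-fold lower number from compound 1 to compound 3 (0.22 log units; within the scatter), so these two cannot be ranked against each other. Compound 2 lies far higher than either, well beyond the scatter.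

Compound 4 `COc1ccc(CN(C(=O)CBr)c2cc(OC)c(OC)c(OC)c2)cc1O` is the next compound. Its difference from compound 3 is bromo in place of chloromethyl on a saturated chain carbon bound to a carbonyl carbon. For the measured compounds named here, only one measured step bears on this: the change from chloro to chloromethyl, which gave a 1.7-fold lower number from compound 1 to compound 3 (0.22 log units; within the scatter) and stayed within the scatter. Going by the values given here, compound 4 undoes that lengthening and at the same time exchanges the halogen, and no measured pair shows what such an exchange does at this position. The expectation is therefore a step of no change at the digits printed from compound 3 to compound 4 (within the scatter), not beyond the scatter. Compound 4 is estimated at 150 nM, with a range from 60 nM to 400 nM.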

Compound 4, half-maximal inhibitory concentration: 68 nM
Estimate against measurement, compound 4: 2.2-fold (0.34 log units) above; measured number inside the range.
By their numbers in this assay, from the lowest: compound 4; then compounds 3 and 1 (each within the scatter of the next); then compound 2.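

In this assay, exchanging chloro for bromo on a saturated chain carbon bound to a carbonyl carbon, with nothing else altered, gives a 3.7-fold lower number from compound 1 to compound 4 (0.57 log units; beyond the scatter) and so is a modest change beyond the scatter, whereas the earlier change from chloro to chloromethyl, a 1.7-fold lower number from compound 1 to compound 3 (0.22 log units; within the scatter), stayed within it. For the compounds shown here, this is the first sign that the number responds to a change at this position, and what changed in this pair is the identity of the halogen. The step of a 2.2-fold lower number from compound 3 to compound 4 (0.34 log units; beyond the scatter) is also modest and beyond the scatter, but it alters the chain and the halogen together, so the pair from compound 1 to compound 4 is the cleaner reading; nothing measured here explains the shift.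

The compounds shown leave open whether the trend from chloro to bromo continues to iodo, and whether bromo keeps its lower number on a longer chain such as 2-bromoethyl. They also leave open what happens when the halogen is replaced by a group such as an amine or a hydroxyl on the same carbon.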